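This account rests on a few compounds, and the source may have more. Where it says the series, first, only, none or still open, it means among the compounds named here.

Compound 2 `O=C([C@H]1CC2CCC1C2)N1CC(c2nc(-c3cccc(F)c3)no2)C1` was measured in an ADME assay on a cell-free system (plasma, Homo sapiens) for protein binding, and gave 99.3%. Among the two compounds measured so far, compound 2 stands with the lowest unbound fraction; compound 1 `O=C(C1CCC(F)(F)CC1)N1CC(c2nc(-c3cccc(Cl)c3)no2)C1`, which in this assay gave 98.7%, lies within the scatter of it, so no order between them can be claimed. The next compound, compound 3 `CC1CCCCC1C(=O)N1CC(c2nc(-c3cccc(F)c3)no2)C1`, differs from compound 2 in one place: a group of 7 heavy atoms (7 carbon; one six-membered non-aromatic ring of carbon only) in place of a group of 7 heavy atoms (7 carbon; 2 five-membered non-aromatic rings of carbon only), on a carbonyl carbon. Going by the values given here, no measured step of this kind is at hand, so the change from compound 2 to compound 3 is expected to stay within the scatter, with a 1.4-fold higher unbound fraction from compound 2 to compound 3 (0.15 log units; within the scatter) as the expected step. For compound 3 the estimate in this assay is 99%, expected between 97.8% and 99.6%.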

Compound 3, plasma protein binding in the plasma assay: 96.6%
For compound 3 the middle estimate is 3.4-fold (0.53 log units) (unbound fraction) below the measured one; the measured number lies below the stated range.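

Going by these compounds alone, at this place on a carbonyl carbon, where the earlier compounds allowed no order, 2-methylcyclohexyl in place of the group with two five-membered rings gives a 4.9-fold higher unbound fraction from compound 2 to compound 3 (0.69 log units; beyond the scatter) in the plasma assay, with the count of heavy atoms unchanged. In a physicochemical assay for solubility, read by HPLC, in phosphate buffer, with a stated time of 4 h (a lower number here means a less soluble compound, a higher number a more soluble compound), compound 2 gives 54000000 nM and compound 3 gives 180000000 nM. The unbound fraction may rise with solubility here, though this rests on a single pair: the measured solubility of compound 2, 54000000 nM, and of compound 3, 180000000 nM, a 3.3-fold higher number (0.52 log units; beyond the scatter)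

The compounds shown leave open whether the methyl group or the six-membered ring accounts for the step. They also leave open how an amine or a carboxylic acid on that ring would read in either assay.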